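A ring replaces an open chain on the shared core

This account rests on a few compounds, and the source may have more. Where it says the series, first, only, none or still open, it means among the compounds named here.

Measured in a functional assay with Oryctolagus cuniculus as the target; a higher number here means a weaker inhibitor, a lower number a stronger inhibitor:
Compound 1 `COc1ccc(-c2nc(CNC(C)=O)sc2-c2ccc(OC)cc2)cc1`: 15 nM.
Compound 2 `COc1ccc(-c2nc(CNC(=O)c3cccnc3)sc2-c2ccc(OC)cc2)cc1`: 25 nM.
Compound 3 `COc1ccc(-c2nc(C(=O)N=C(N)N)sc2-c2ccc(OC)cc2)cc1`: > 100 nM.

For compound 3, > 100 nM is a limit of the assay, not a number. The data show an at least 6.6-fold higher number from compound 1 to compound 3 (0.82 log units; beyond the scatter), and also an at least 4.0-fold higher number from compound 2 to compound 3 (0.60 log units; beyond the scatter), so changing the group at this place can matter. By contrast, the data show a 1.7-fold higher number from compound 1 to compound 2 (0.22 log units; within the scatter). Compound 4 `COc1ccc(-c2nc(C3=NNC(=O)CC3)sc2-c2ccc(OC)cc2)cc1` carries a group of 7 heavy atoms (4 carbon, 2 nitrogen, 1 oxygen; one six-membered non-aromatic ring with 2 hetero atoms) in place of a group of 6 heavy atoms (2 carbon, 3 nitrogen, 1 oxygen; no ring), on an aromatic carbon. Within the data shown here, no measured compound has this ring, so the forecast is uncertain. It leans towards compound 1 at 15 nM and compound 2 at 25 nM. The expected change is an at least 2.5-fold lower number from compound 3 to compound 4 (0.39 log units; beyond the scatter), towards a lower number. In this assay the estimate for compound 4 is 40 nM, expected between 8 nM and 150 nM.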

Compound 4, half-maximal inhibitory concentration: > 1000 nM
Compound 4: no number, only a limit; the forecaster's own chance of this, stated with the estimate: 25%; middle value at least 25-fold (1.39 log units) away from the limit.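

In this assay compound 4 gives > 1000 nM, which is a limit of the assay and not a number. The ring brings an at least 66-fold higher number from compound 1 to compound 4 (1.82 log units; beyond the scatter) and an at least 40-fold higher number from compound 2 to compound 4 (1.60 log units; beyond the scatter), so this position accepts a pyridin-3-yl at the end of a chain but not this six-membered non-aromatic ring set on the aromatic carbon itself. The step between compound 3 and compound 4 cannot be read, because both values are limits: the limit of > 1000 nM in this assay, at which 1 of the 4 values shown sits.

The compounds shown leave open how an amine or a carboxylic acid would fare at this place. They also leave open whether a six-membered aromatic ring on this same carbon would bring a similar loss.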